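The source may report more compounds than this note shows. Statements on the series, on what has been measured and on what is new or still open speak of the compounds shown alone.

Measured in a toxicity assay on the whole organism (strain Icem-CET (SPF Caw)) for cytotoxicity, with Mus musculus as the target (a higher number here means that more compound is needed for the effect, a lower number that less compound is needed), so far:
compound 1 `C/C(C(=O)NC1CC1)=C(/C)c1ccc(F)cc1` – 200 mg/kg
compound 2 `C/C(C(=O)NC1CC1)=C(/C)c1ccccc1` – 250 mg/kg
compound 3 `C/C(C(=O)NC1CC1)=C(/C)c1ccc(Cl)cc1` – > 800 mg/kg

The value of compound 3 is a limit of the assay, not a number (the limit of > 800 mg/kg in this assay, at which 1 of the 3 values shown sits). Compound 4 `C/C(C(=O)NC1CC1)=C(/C)c1ccc(C)cc1` differs from compound 3 by methyl in place of chloro on an aromatic carbon. Going by the values given here, two measured steps touch the same aromatic carbon: an at least 4.0-fold higher number from compound 1 to compound 3 (0.60 log units; beyond the scatter) and an at least 3.2-fold higher number from compound 2 to compound 3 (0.50 log units; beyond the scatter), both beyond the scatter, in each case with chloro entering. The step of a 1.3-fold higher number from compound 1 to compound 2 (0.10 log units; within the scatter) stays within the scatter. Among the compounds with values here, no measured step here covers methyl at that carbon, so the expectation rests on the removal of chloro: a modest step downward in this assay, an at least 1.6-fold lower number from compound 3 to compound 4 (0.20 log units; that floor lies within the scatter), expected to leave compound 4 between the limit of compound 3 and the values of compound 1 and compound 2. The estimate for compound 4 is 500 mg/kg, in the range 220 mg/kg to 1200 mg/kg.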

Compound 4, dose for half-maximal effect: 300 mg/kg
Beside the measured number, compound 4's estimate is 1.7-fold (0.22 log units) above it; measured number inside the range.
By their numbers in this assay, from the lowest: compounds 1, 2 and 4 (each within the scatter of the next). At a limit, above all of these: compound 3.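

In this assay, methyl at this aromatic carbon does not separate from hydrogen or fluoro: a 1.2-fold higher number from compound 2 to compound 4 (0.08 log units; within the scatter) and a 1.5-fold higher number from compound 1 to compound 4 (0.18 log units; within the scatter). Against chloro the picture differs, with an at least 2.6-fold lower number from compound 3 to compound 4 (0.42 log units; beyond the scatter), so among the four groups at this carbon only chloro stands apart. The value of compound 3 is a limit, not a number: the limit of > 800 mg/kg in this assay, at which 1 of the 4 values shown sits.

Going by these compounds, whether bromo, an amine or a longer chain at this carbon would fall with compound 4 or with compound 3 stays open. On these data alone, how far compound 3 truly lies from the others also stays open.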